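The compounds below may be only part of what the source reports. "The series", "measured", "known", "first", "only" and "open" are said of these compounds alone.

Series notes, antiproliferative read-out.

- compound 1 `COc1cc(C(=O)N/N=C/c2cccc(F)c2)cc(OC)c1OC`: 64.1%
- compound 2 `COc1cc(C(=O)N/N=C/c2cccc(C(F)(F)F)c2)cc(OC)c1OC`: 79.8%

In a functional assay on PC-3 cells (Homo sapiens) for antiproliferative activity, read by MTT assay, tested at 5 uM (on this read-out higher numbers stand for a stronger effect at the one concentration tested and lower numbers for a weaker effect), compound 1 stands lowest of the two numbers measured; its nearest neighbour is compound 2, and the step of a number 15.7 percentage points higher from compound 1 to compound 2 (beyond the scatter) lies beyond the scatter. The unmeasured compound 3 `COc1cc(C(=O)N/N=C/c2ccc(F)cc2)cc(OC)c1OC` differs from compound 1 by 4-fluorophenyl in place of 3-fluorophenyl on a carbon with a double bond to nitrogen. Among the measured compounds shown here, no measured step bears on this change: the one step known, a number 15.7 percentage points higher from compound 1 to compound 2 (beyond the scatter), concerns trifluoromethyl in place of fluoro on an aromatic carbon, not 4-fluorophenyl in place of 3-fluorophenyl, so it gives neither size nor direction for the step to compound 3. With no matching comparison, the expectation for compound 3 is a step of no size beyond the scatter, a number 0.1 percentage points lower from compound 1 to compound 3 (within the scatter). Compound 3 is therefore estimated at 64% in this assay, with a range from 45% to 82%.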

Compound 3, a percentage reported as inhibition, at one concentration (the size of the read-out at that concentration, not a potency): 82.8%
Compound 3: middle estimate off by 18.8 percentage points, on the low side, outside the stated range (above it).
By their numbers in this assay, from the lowest: compound 1; then compounds 2 and 3 (each within the scatter of the next).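

In this assay, the place of the fluorine on the aryl group carried by the carbon with a double bond to nitrogen counts: 4-fluorophenyl in place of 3-fluorophenyl, with the same heavy atoms, gives a number 18.7 percentage points higher from compound 1 to compound 3 (beyond the scatter) at the one concentration tested. The earlier step at this aryl group, a number 15.7 percentage points higher from compound 1 to compound 2 (beyond the scatter) with trifluoromethyl in place of fluoro, changed the substituent itself, whereas this step shows that the read-out also responds when the substituent stays the same and only its place changes. Nothing at hand gives a reason for this step.

Open, as far as these compounds go, is whether the gain is particular to fluoro or also appears with chloro, methoxy or amino in its place on the ring of compound 3. The compounds shown also leave open whether the same change of place would carry over to trifluoromethyl.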